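The source may report more compounds than this note shows. Statements on the series, on what has been measured and on what is new or still open speak of the compounds shown alone.

Two compounds share one core, on which a thiocarbonyl carbon carries a cyclic amine. Compound 1 `N/C(=N\NC(=S)N1CCSCC1)c1ccccn1` carries thiomorpholin-4-yl there, and in a functional assay on MCF7 cells (Homo sapiens) for cytotoxicity, read by MTT assay, with a stated time of 72 h (on this read-out lower numbers stand for stronger inhibition and higher numbers for weaker inhibition), compound 1 gives 8800 nM. Compound 2 `N/C(=N\NC(=S)N1CCCCC1)c1ccccn1` carries piperidin-1-yl instead, and in this assay compound 2 gives 8500 nM. The step of a 1.0-fold lower number from compound 1 to compound 2 (0.02 log units; within the scatter) lies within the scatter, so on the two numbers available compound 2 stands alongside compound 1, and neither can be called the stronger.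

Compound 3 `Cc1cccc(/C(N)=N/NC(=S)N2CCCCC2)n1` has not yet been measured. It differs from compound 2 in one place only: methyl in place of hydrogen on an aromatic carbon, on an aromatic carbon of a six-membered aromatic ring with one nitrogen, next to the ring nitrogen and meta to a large group. For the measured compounds named here, no measured step touches that ring; the only step available, from compound 1 to compound 2, concerns the amine on the thiocarbonyl carbon and stayed within the scatter, so it gives no guide for a methyl on the aromatic ring. With nothing pointing either way, the expected step of no change at the digits printed from compound 2 to compound 3 (within the scatter) is none beyond the scatter. Compound 3 is therefore estimated at 8500 nM in this assay, with a range from 3500 nM to 20000 nM.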

Compound 3, half-maximal inhibitory concentration: 74000 nM
Beside the measured number, compound 3's estimate is 8.7-fold (0.94 log units) below it; measured number outside the range, above it.
By their numbers in this assay, from the lowest: compounds 2 and 1 (each within the scatter of the next); then compound 3.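

In this assay, this place on the aromatic ring proves sensitive: adding one methyl, a single heavy atom with no hydrogen-bond donors or acceptors, gives an 8.7-fold higher number from compound 2 to compound 3 (0.94 log units; beyond the scatter), a shift towards weaker inhibition. The earlier pair showed only that exchanging the cyclic amine on the thiocarbonyl carbon left the number within the scatter, so this is the first change among the compounds shown to move it beyond the scatter, and it lies on the aromatic ring rather than on the amine. Nothing in the data at hand speaks to why the number rose.

From the compounds shown here alone, it remains open whether this weakening belongs to methyl itself or would follow any group at this place, which an ethyl group, a chlorine atom or a methoxy group on the same carbon could help to separate. Going by these compounds, it is also open whether a methyl on another aromatic carbon of the ring would shift the number as far, and whether this methyl would do the same with thiomorpholin-4-yl in place of piperidin-1-yl on the thiocarbonyl carbon.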